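The source may report more compounds than this note shows. Statements on the series, on what has been measured and on what is new or still open speak of the compounds shown alone.

Compound 1 `CCc1cc(C)c(C(=O)N=C(N)N)cc1S(C)(=O)=O`: 4.8 nM
Compound 2 `CS(=O)(=O)c1cc(C(=O)N=C(N)N)ccc1-n1cccn1`: 160 nM
Compound 3 `Cc1cc(-n2cccn2)c(S(C)(=O)=O)cc1C(=O)N=C(N)N`: 25 nM

In a functional assay for inhibition of sodium/hydrogen exchanger (Oryctolagus cuniculus) (a lower number here means a stronger inhibitor, a higher number a weaker inhibitor), compound 2 gives the highest number of the three measured compounds; compound 3 is its nearest neighbour, and compound 1 lies furthest from it. Compound 4 `CS(=O)(=O)c1cc(C(=O)N=C(N)N)ccc1C1CCCCC1` has not yet been measured. It differs from compound 2 in one place: cyclohexyl in place of 1H-pyrazol-1-yl on an aromatic carbon. Of the measured steps, the one that bears on this change is a 5.2-fold higher number from compound 1 to compound 3 (0.72 log units; beyond the scatter), where putting 1H-pyrazol-1-yl in place of an alkyl group on the aromatic carbon raised the number. Compound 4 goes the opposite way, replacing the 1H-pyrazol-1-yl with a ring of carbon only, so a lower number is expected. The other step, a 6.4-fold lower number from compound 2 to compound 3 (0.81 log units; beyond the scatter), concerns a methyl in place of hydrogen and does not speak to this change directly. Compound 4 is therefore expected to show a modest step down, a 4.0-fold lower number from compound 2 to compound 4 (0.60 log units; beyond the scatter). Compound 4 is estimated at 40 nM, with a likely range from 10 nM to 160 nM.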

Compound 4, half-maximal inhibitory concentration: 340 nM
Estimate against measurement, compound 4: 8.5-fold (0.93 log units) below, outside the stated range (above it).
By their numbers in this assay, from the lowest: compound 1; then compound 3; then compound 2; then compound 4.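

In this assay, cyclohexyl in place of 1H-pyrazol-1-yl on the aromatic carbon ortho to the methylsulfonyl group gives a 2.1-fold higher number from compound 2 to compound 4 (0.33 log units; beyond the scatter), a modest step that lies beyond the scatter. The earlier step, a 5.2-fold higher number from compound 1 to compound 3 (0.72 log units; beyond the scatter), with 1H-pyrazol-1-yl in place of ethyl, made the pyrazole look like the poorer group at this carbon, yet here it is the better of the pair. Replacing the pyrazole with a group of carbon only therefore does not lower the number in every case: the result depends on the group that enters, on the core (compound 3 carries a methyl that compound 2 lacks), or on both.

Nothing shown explains this reversal. Still open, as far as these compounds go, is how a phenyl ring or an amine such as piperidin-1-yl would compare with 1H-pyrazol-1-yl at this carbon, and whether cyclohexyl would behave the same way on the methyl-bearing core.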